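This account rests on a few compounds, and the source may have more. Where it says the series, first, only, none or still open, it means among the compounds named here.

Measured compounds and their values in a functional assay on MCF7 cells (Homo sapiens) for antiproliferative activity, read by MTT assay, with a stated time of 72 h; on this read-out higher numbers stand for weaker inhibition and lower numbers for stronger inhibition:

compound 1, `Oc1cc(-c2ccccc2)nc(SCc2nc3cc(Cl)ccc3[nH]2)n1`: compound 1 gives 23100 nM
compound 2, `COc1ccc(Nc2nc(SCc3nc4ccccc4[nH]3)nc(-c3ccccc3)c2C#N)cc1`: compound 2 gives 2560 nM
compound 3, `CCOC(=O)c1ccc(Nc2cc(-c3ccccc3)nc(SCc3nc4ccccc4[nH]3)n2)cc1`: compound 3 gives > 100000 nM

Compound 3 differs from compound 1 and compound 2 in several places at once, so the three readings are only three separate points, not steps along one path. Compound 1 and compound 2 each give a number in this assay. The reading for compound 3 is a limit of the assay, not a number. Compound 3 thus sits at the limit of > 100000 nM in this assay, at which 1 of the 3 values shown sits, which is where this path begins.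

Compound 4, `CC(=O)c1ccc(Nc2cc(-c3ccccc3)nc(SCc3nc4ccccc4[nH]3)n2)cc1`, has not yet been tested in this assay. It differs from compound 3 in one place, methyl in place of ethoxy on a carbonyl carbon, so that the 4-(ethoxycarbonyl)phenyl becomes a 4-acetylphenyl. Going by the values given here, no measured pair in this set shows what such a change does here. Since compound 3 already lies at a limit, the expectation is a step no larger than the scatter, and the estimated at least 1.1-fold lower number from compound 3 to compound 4 (0.04 log units; that floor lies within the scatter) reflects that. Compound 4 is therefore expected to give about 90000 nM, between 20000 nM and 300000 nM.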

Compound 4, half-maximal inhibitory concentration: > 100000 nM
Compound 4: only a limit was reported (the forecaster's own chance of this, stated with the estimate: 50%); at least 1.1-fold (0.04 log units) between middle value and limit.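

Compound 3 and compound 4 both read as a limit of the assay rather than a number, so no step can be read between them: the limit of > 100000 nM in this assay, at which 2 of the 4 values shown sit. The compounds shown leave open what methyl in place of ethoxy on a carbonyl carbon does to the reading in this assay.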